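Removing one fluoro from a trifluorobenzyl group

The compounds below may be only part of what the source reports. "The series", "measured", "known", "first", "only" and "open" are said of these compounds alone.

Measured so far in an in vitro assay on HEK293 cells for displacement of a labelled ligand from adenosine receptor A2b (Homo sapiens); on this read-out lower numbers stand for stronger inhibition and higher numbers for weaker inhibition:
Compound 1, `CCCn1c(=O)c2nc(-c3cnn(Cc4c(F)cccc4F)c3)[nH]c2n(CCC)c1=O`, gives 390 nM.
Compound 2, `CCCn1c(=O)c2nc(-c3cnn(Cc4cc(F)ccc4Cl)c3)[nH]c2n(CCC)c1=O`, gives 4800 nM.
Compound 3, `CCCn1c(=O)c2nc(-c3cnn(Cc4c(F)cc(F)cc4F)c3)[nH]c2n(CCC)c1=O`, gives 650 nM.

Compound 3 stands second highest of the three; it sits close to compound 1, while the gap on its other side is real (a 7.4-fold lower number from compound 2 to compound 3 (0.87 log units; beyond the scatter)). Compound 4, `CCCn1c(=O)c2nc(-c3cnn(Cc4ccc(F)cc4F)c3)[nH]c2n(CCC)c1=O`, differs from compound 3 by a single change: hydrogen in place of fluoro on an aromatic carbon. Going by the values given here, the closest precedent is the step from compound 1 to compound 3, in which one fluoro was added to the same ring and the result stayed within the scatter (a 1.7-fold higher number from compound 1 to compound 3 (0.22 log units; within the scatter)). Reshaping the halogen pattern more thoroughly mattered greatly (a 12-fold higher number from compound 1 to compound 2 (1.09 log units; beyond the scatter)), but that swapped two groups at once. For compound 4 the step is therefore expected to be small, a 1.1-fold higher number from compound 3 to compound 4 (0.03 log units; within the scatter), giving an estimate of 700 nM, between 300 nM and 1800 nM.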

Compound 4, inhibition constant: 700 nM
The estimate for compound 4 equals the measured number at the digits printed, within the range that was stated.
By their numbers in this assay, from the lowest: compounds 1, 3 and 4 (each within the scatter of the next); then compound 2.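

In this assay, the fluoro ortho to a large group can be replaced by hydrogen with no change beyond the scatter (a 1.1-fold higher number from compound 3 to compound 4 (0.03 log units; within the scatter)), and the 2,4-difluorophenyl group matches the 2,6-difluorophenyl group in the same way (a 1.8-fold higher number from compound 1 to compound 4 (0.25 log units; within the scatter)). Compound 4 still stands clearly apart from the chloro-bearing compound 2 (a 6.9-fold lower number from compound 2 to compound 4 (0.84 log units; beyond the scatter)). No evidence here bears on why these steps came out this way.

As far as these compounds go, whether a methoxy group or an amine would be accepted on this aromatic carbon remains open. So does which halogen change in compound 2 accounts for its weaker number.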